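The compounds below may be only part of what the source reports. "The series", "measured", "known", "first", "only" and "open" are said of these compounds alone.

Compound 1 `CCN(CC)c1nc(Cl)nc(NC(C)c2ccccc2)n1` is the reference point of this set. In an ADME assay on the whole organism for inhibition, with Echinochloa crus-galli var. formosensis as the target, with a stated time of 4 days (on this read-out lower numbers stand for stronger inhibition and higher numbers for weaker inhibition), compound 1 gives 1510 nM, the lowest of the three numbers; compound 2 `CC(C)Nc1nc(Cl)nc(N[C@H](C)c2ccccc2)n1` gives 2000 nM, within the scatter of it, and compound 3 `CC[C@@H](C)Nc1nc(Cl)nc(N[C@H](C)c2ccccc2)n1` gives 4570 nM, beyond the scatter. Within the data shown here, the only single-place step in the set, a 2.3-fold higher number from compound 2 to compound 3 (0.36 log units; beyond the scatter), concerns a methyl on the other amine and says nothing about the stereocentre. Compound 4 `CCN(CC)c1nc(Cl)nc(N[C@@H](C)c2ccccc2)n1` differs from compound 1 only in that (the two compounds have the same atoms and bonds; at least one stereo element is drawn with a configuration in one of them and without one in the other: 1 of 1 stereo elements differ; a stereocentre at a saturated chain carbon is drawn without a configuration in compound 1 and S in compound 4). Among the measured compounds shown here, no measured step bears on such a change, so no step beyond the scatter is expected; the step from compound 1 to compound 4 is estimated at a 1.3-fold lower number from compound 1 to compound 4 (0.10 log units; within the scatter). Compound 4 is expected to give about 1200 nM, with a range from 500 nM to 3500 nM.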

Compound 4, half-maximal inhibitory concentration: 257 nM
Compound 4: the middle estimate sits 4.7-fold (0.67 log units) above what was measured, and the stated range ends above it.
By their numbers in this assay, from the lowest: compound 4; then compounds 1 and 2 (each within the scatter of the next); then compound 3.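

At the saturated chain carbon, configuration alone moves the numbers in this assay: the S drawing comes with a 5.9-fold lower number from compound 1 to compound 4 (0.77 log units; beyond the scatter). Among these compounds, the earlier step lay on the other amine, so this is the first reading at the stereocentre itself. Nothing else separates the pair: the fact that one of compounds 1 and 4 is drawn with a defined configuration and the other without, at the place where they differ

Going by these compounds, the drawing of compound 1 does not tell what it holds at that carbon, so the place of the opposite configuration stays open. Also open, on these data alone, is whether the S drawing counts for as much with a morpholine or a longer chain on the other amine.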